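The source may report more compounds than this note shows. Statements on the series, on what has been measured and on what is new or still open speak of the compounds shown alone.

Series notes. Compound 1 `CC(=O)OCc1ccc2oc(=O)c(C(=O)Sc3cccc(Cl)c3)cc2c1` carries a chloro group that compound 2 `CC(=O)OCc1ccc2oc(=O)c(C(=O)Sc3cccc(Br)c3)cc2c1` exchanges for bromo, a change described as bromo in place of chloro on an aromatic carbon. In a functional assay on HT-1080 cells (Homo sapiens), read by transwell migration, with a stated time of 24 h, tested at 1 uM (a lower number here means a stronger effect, a higher number a weaker effect of the compound at the concentration tested), compound 1 gives 65.8%, and compound 2 gives 70.9%; the step of a number 5.1 percentage points higher from compound 1 to compound 2 (within the scatter) is small. Compound 3 `O=C(Oc1cccc(Cl)c1)c1cc2cc([N+](=O)[O-])ccc2oc1=O` rests on a different core, and the difference between the two cores is not broken down here; in this assay compound 3 gives 65.8%, level with compound 1 at the digits printed. Compound 4 `O=C(Oc1cccc(Br)c1)c1cc2cc([N+](=O)[O-])ccc2oc1=O` is not yet measured. It differs from compound 3 by bromo in place of chloro on an aromatic carbon, the same change as before, at a place described in the same words. For compound 4 the step in this assay is expected to be equally small, estimated at a number 4.2 percentage points higher from compound 3 to compound 4 (within the scatter), because the earlier step of a number 5.1 percentage points higher from compound 1 to compound 2 (within the scatter) was small. Compound 4 is therefore estimated at 70%, with a likely range from 58% to 82%.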

Compound 4, a percentage reported as activity, at one concentration (the size of the read-out at that concentration, not a potency): 35.2%
Beside the measured number, compound 4's estimate is 34.8 percentage points above it; measured number outside the range, below it.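

On the core of compound 3, bromo in place of chloro gives a number 30.6 percentage points lower from compound 3 to compound 4 (beyond the scatter) in this assay, so a step read on one core cannot be carried over to the other in this series: the same change on two cores in this assay, a number 5.1 percentage points higher (within the scatter) from compound 1 to compound 2 and a number 30.6 percentage points lower (beyond the scatter) from compound 3 to compound 4, 35.7 percentage points apart, beyond the scatter of two such steps

The two cores differ in more than one place, and these pairs do not show which of those differences goes with the gap between the steps. Two pairs tested at a single concentration also give no rule for this exchange on any further core.

Open, going by these compounds, is how a fluoro or methoxy group in place of the bromo would read on the core of compound 4. Also open, on these data alone, is what an amine in place of the nitro group would do to the step.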